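This account rests on a few compounds, and the source may have more. Where it says the series, first, only, none or still open, it means among the compounds named here.

In a functional assay on the whole organism for antagonist activity, with Mus musculus as the target, in the maximal electroshock model (on this read-out higher numbers stand for an effect only at larger amounts of compound and lower numbers for an effect already at smaller amounts), compound 1 `CCS(=O)(=O)c1nnc(-c2ccccc2)n1C` gives > 200 mg/kg, which is a limit. Compound 2 `Cn1c(-c2ccccc2F)nnc1[S+](C)[O-]` gives > 200 mg/kg, also a limit. Compound 3 `Cn1c(-c2ccccc2F)nnc1S(C)(=O)=O` gives > 100 mg/kg, and this too is only a limit, so it has no numeric position among the values shown.

Compound 4 `CCS(=O)(=O)c1nnc(-c2ccccc2F)n1C` differs from compound 3 by methyl in place of hydrogen on a saturated chain carbon bound to a sulfonyl sulfur, with methyl in place of hydrogen on a saturated chain carbon bound to a sulfonyl sulfur, so that methylsulfonyl becomes ethylsulfonyl. Going by the values given here, the only measured step, a step that the two limits leave unreadable from compound 2 to compound 3, changes a different feature of the sulfur group and offers no size to carry over. Compound 1 already carries ethylsulfonyl, yet its > 200 mg/kg is again a limit. With no numeric value among these compounds, no shift beyond the usual scatter is expected in this assay, and no direction can be assigned. The estimated step is a step that the limit leaves unreadable from compound 3 to compound 4. For compound 4 the expected value is 150 mg/kg, with an estimated range from 60 mg/kg to 300 mg/kg, and the assay may well report only a limit again.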

Compound 4, dose for half-maximal effect: > 200 mg/kg
Compound 4: no number, only a limit (the forecaster's own chance of this, stated with the estimate: 75%); middle value at least 1.3-fold (0.12 log units) from the limit.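

In this assay compound 4 gives > 200 mg/kg, which is a limit, so none of its steps from compound 1, compound 2 or compound 3 can be read. The compounds shown leave open whether ethylsulfonyl in place of methylsulfonyl, or fluoro in place of hydrogen, changes the read-out at all.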